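A few compounds are considered here, and "the series" means these few. Any claim that something is new, unique, unknown or untested is made for them only; others in the source may bear on it.

Compound 1 `CCCCCC/C=C/c1ccc(CO[C@@H]2CN[C@@H](CO)C2)cc1` gives 1400 nM in a functional assay on FL5.12 cells (Mus musculus) for cytotoxicity, read by flow cytometry, with a stated time of 48 h; a lower number here means a stronger inhibitor, a higher number a weaker inhibitor.
Compound 2 `CCCCCCCCCC/C=C/c1ccc(CO[C@@H]2CN[C@@H](CO)C2)cc1` gives 2800 nM in this assay.
Compound 3 `CCCCCC/C=C/c1ccc(CO[C@H]2CN[C@H](CO)C2)cc1` gives 2400 nM in this assay.

Compound 4 `CCCCCCCCCC/C=C/c1ccc(CO[C@H]2CN[C@H](CO)C2)cc1` has not yet been measured.

Compound 2 arises from compound 1 through one change, (butyl in place of hydrogen on a saturated chain carbon, six bonds along the chain from a double-bonded chain carbon), and that change produced a 2.0-fold higher number from compound 1 to compound 2 (0.30 log units; within the scatter). Compound 3 is built from the same atoms and bonds as compound 1 and differs from it only as follows: the two compounds have the same atoms and bonds and differ only in configuration as drawn: 2 of 3 stereo elements differ; a stereocentre at a saturated ring carbon is drawn S in compound 1 and R in compound 3; a stereocentre at a saturated ring carbon is drawn R in compound 1 and S in compound 3. The measured step of a 1.7-fold higher number from compound 1 to compound 3 (0.23 log units; within the scatter) rests on (the fact that compounds 1 and 3 differ only in the configuration as drawn), and no other difference between the two cores is broken down here.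

Compound 4 arises from compound 3 through (butyl in place of hydrogen on a saturated chain carbon, six bonds along the chain from a double-bonded chain carbon). Going by the values given here, this is the same change that turns compound 1 into compound 2, made at the same place on the chain, so the earlier step is the only guide to what it will do. In this assay the change from compound 3 to compound 4 is therefore expected to give a 1.9-fold higher number from compound 3 to compound 4 (0.27 log units; within the scatter), an expectation that rests on a 2.0-fold higher number from compound 1 to compound 2 (0.30 log units; within the scatter). Compound 4 is accordingly estimated at 4500 nM in this assay. Its likely range is estimated to run from 2000 nM to 10000 nM.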

Compound 4, half-maximal inhibitory concentration: 2400 nM
Estimate against measurement, compound 4: 1.9-fold (0.27 log units) above, within the range that was stated.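

In this assay, butyl in place of hydrogen on the core of compound 3 gives no change at the digits printed from compound 3 to compound 4 (within the scatter), and the two long-chain compounds, which differ only in configuration as drawn, show a 1.2-fold lower number from compound 2 to compound 4 (0.07 log units; within the scatter). Set side by side, the steps on the two cores cannot be told apart: the same change on two cores in this assay, a 2.0-fold higher number (0.30 log units; within the scatter) from compound 1 to compound 2 and no change at the digits printed (within the scatter) from compound 3 to compound 4, 2.0-fold (0.30 log units) apart, within the scatter of two such steps. The change therefore carries across these cores in a limited sense, since it moves the number beyond the scatter on neither of them, but this rests on one pair of cores in one assay and shows only that no large effect appears, not that both cores share an effect of any particular size.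

Still open, on these data alone, is whether a much longer chain, or a chain ending in an amine or a carboxylic acid, would move the number beyond the scatter on either core. Going by these compounds alone, also open is how a core would behave with only one of its ring stereocentres inverted.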